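Ring-nitrogen substituent swap: compound 3 to compound 4

A few compounds are considered here, and "the series" means these few. Any claim that something is new, unique, unknown or untested is made for them only; others in the source may bear on it.

The series shares one core; compound 1 `COc1ccc(-c2cnc3nc(N)nc(N4CCN(C(=O)NCc5ccccc5)CC4)c3n2)cc1OC`, compound 2 `COc1ccc(-c2cnc3nc(N)nc(N4CCN(C(=O)COc5ccccc5)CC4)c3n2)cc1OC` and compound 3 `COc1ccc(-c2cnc3nc(N)nc(N4CCN(c5cc(Cl)cc(Cl)c5)CC4)c3n2)cc1OC` differ only in the group on the ring nitrogen. In a functional assay on cells (T-cell, Homo sapiens) for inhibition (a higher number here means a weaker inhibitor, a lower number a stronger inhibitor), compound 1 gives 18 nM, compound 2 gives 4 nM and compound 3 gives 3400 nM, so compound 3 stands highest of the three numbers, nearest to compound 1 and furthest from compound 2. The two carbonyl-bearing groups give the two low numbers, with a modest gap: a 4.5-fold lower number from compound 1 to compound 2 (0.65 log units; beyond the scatter). Replacing either carbonyl-bearing group by an aryl group set directly on the ring nitrogen raises the number sharply: a 190-fold higher number from compound 1 to compound 3 (2.28 log units; beyond the scatter) and an 850-fold higher number from compound 2 to compound 3 (2.93 log units; beyond the scatter).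

Compound 4 `COc1ccc(-c2cnc3nc(N)nc(N4CCN(Cc5ccccc5F)CC4)c3n2)cc1OC` is to be measured in this assay. Its change from compound 3: 2-fluorobenzyl in place of 3,5-dichlorophenyl on an amine nitrogen in a ring. Going by the values given here, no measured step covers a benzyl group on this ring nitrogen; the entering group keeps one six-membered aromatic ring of carbon only, but it is neither a directly attached aryl as in compound 3 nor a carbonyl-bearing group as in compounds 1 and 2. The large rises into compound 3 are expected to reverse in part, not fully. The expected step is a 17-fold lower number from compound 3 to compound 4 (1.23 log units; beyond the scatter). Compound 4 is estimated at 200 nM, with a range from 30 nM to 1500 nM.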

Compound 4, half-maximal inhibitory concentration: 700 nM
Compound 4: the middle estimate sits 3.5-fold (0.54 log units) below what was measured; the range from low to high includes it.
By their numbers in this assay, from the lowest: compound 2; then compound 1; then compound 4; then compound 3.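

In this assay a 2-fluorobenzyl group on the amine nitrogen in the ring gives back only part of what the aryl group lost, with a 4.9-fold lower number from compound 3 to compound 4 (0.69 log units; beyond the scatter) while the number remains well short of the carbonyl-bearing groups, as seen in a 180-fold higher number from compound 2 to compound 4 (2.24 log units; beyond the scatter) and in a 39-fold higher number from compound 1 to compound 4 (1.59 log units; beyond the scatter) on the same nitrogen. Going by these compounds alone, the entering and leaving groups have the same counts of heavy atoms, aromatic rings, hydrogen-bond donors and acceptors, yet the number still moves beyond the scatter, and among the four compounds both carbonyl-bearing groups give lower numbers than both groups without a carbonyl, with no compound going against this. No measured evidence on the reason for this step is available.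

The compounds shown leave open whether the step follows from the added carbon link or from the change of halogens, which a plain benzyl group and a 3,5-dichlorobenzyl group on this nitrogen would separate. Also open, going by these compounds, is whether the carbonyl alone goes with the low numbers or needs the aromatic ring further out, a question that a simple acetyl group at this position would address.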